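This account rests on a few compounds, and the source may have more. Where it says the series, first, only, none or still open, it means among the compounds named here.

Notes on the series. Two compounds carry measurements so far: compound 1 `Cc1ccc(-c2c(S(=O)(=O)c3ccccc3)cnc3cc(C)nn23)cc1` and compound 2 `Cc1ccc(-c2c(S(=O)(=O)c3ccccc3)cnc3ncnn23)cc1`. In a functional assay on the whole organism for inhibition, with Mus musculus as the target, with a stated time of 4 h, at a dose of 50 mg/kg by the oral route (a lower number here means less inhibition, a higher number more inhibition at the dose given (going by the name of the read-out)), compound 1 gives 14%. In this assay compound 2 gives 3.3%, the lowest of the two numbers, with compound 1 standing higher by a margin beyond the scatter. Going by the values given here, no pair that differs in one place has been measured, so no step size is known.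

Compound 3 `O=S(=O)(c1ccccc1)c1cnc2ncnn2c1-c1ccc(Br)cc1` is to be measured in this assay. Against compound 2 the change is bromo in place of methyl on an aromatic carbon, para to a large group. Among the compounds with values here, with compound 2 at 3.3% and no step measured, the step of a number 4.7 percentage points higher from compound 2 to compound 3 (within the scatter) is expected to be small, in either direction, and not beyond the scatter. In this assay compound 3 is expected to give about 8%, with a range from 0% to 25%.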

Compound 3, a percentage reported as inhibition, in the whole organism at one dose (the size of the read-out at that dose, not a potency): 1.3%
Estimate against measurement, compound 3: 6.7 percentage points above, and the stated range covers the measured number.
By their numbers in this assay, from the lowest: compounds 3 and 2 (each within the scatter of the next); then compound 1.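

In this assay the series now has its first measured step: bromo in place of methyl on an aromatic carbon, para to a large group, gives a number 2 percentage points lower from compound 2 to compound 3 (within the scatter) and so does not separate the two compounds. On the core of compound 2, then, the change from 4-methylphenyl to 4-bromophenyl makes no difference that can be told from the scatter of this read-out. No measurement at hand bears on what lies behind this result.

Whether an amine, a carboxylic acid or a methoxy group at this place would give a step beyond the scatter stays open, since only methyl and bromo are shown there. Also open, on these data alone, is whether bromo in place of methyl would give a similar step on the core of compound 1.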